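Shortening the Ether Chain from Compound 3 to Compound 4

This account rests on a few compounds, and the source may have more. Where it says the series, first, only, none or still open, it means among the compounds named here.

Among the measured compounds shown here, compound 3 `O=C(/C=C/c1ccc(O)cc1)c1c(O)cccc1OCCC1CCCC1` is the only one of the three compounds that gives a number in an assay on THP-1 cells for inhibition of nuclear factor NF-kappa-B complex (Homo sapiens), with stated times of 2 h and 16 h; a lower number here means a stronger inhibitor, a higher number a weaker inhibitor; there compound 3 gives 18000 nM. Compound 1 `CC(C)=CCOc1cccc(O)c1C(=O)/C=C/c1ccc(O)cc1` reaches only the limit of the assay, > 30000 nM. Compound 2 `COc1cccc(OCCC(C)(C)C)c1C(=O)/C=C/c1ccc(O)cc1` likewise reaches only the limit, > 30000 nM. For the measured compounds named here, the single measured step is an at least 1.6-fold lower number from compound 1 to compound 3 (0.22 log units; that floor lies within the scatter). Compound 4 `O=C(/C=C/c1ccc(O)cc1)c1c(O)cccc1OCC1CCCC1` differs from compound 3 by cyclopentyl in place of cyclopentylmethyl on a saturated chain carbon bound to an oxygen on an aromatic ring. Going by the values given here, no measured step alters the chain length between the ring and the oxygen, so that step bears only loosely on this change, and in view of the limit of > 30000 nM in this assay, at which 2 of the 3 values shown sit, no shift beyond the scatter is expected. The estimate for compound 4 is 20000 nM, between 8000 nM and 50000 nM. The expected step is a 1.1-fold higher number from compound 3 to compound 4 (0.05 log units; within the scatter).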

Compound 4, half-maximal inhibitory concentration: 13000 nM
For compound 4 the middle estimate is 1.5-fold (0.19 log units) above the measured one, within the range that was stated.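

Replacing cyclopentylmethyl with cyclopentyl at this position gives a 1.4-fold lower number from compound 3 to compound 4 (0.14 log units; within the scatter), so these two chain lengths cannot be told apart in this assay. Cyclopentyl in place of 2-methylprop-1-en-1-yl gives the first step in this series beyond the scatter, an at least 2.3-fold lower number from compound 1 to compound 4 (0.36 log units; beyond the scatter). That step is only a floor resting on a limit of the assay: the limit of > 30000 nM in this assay, at which 2 of the 4 values shown sit.

The compounds shown leave open whether a cyclohexyl ring, a longer chain or an amine on the chain would shift the number beyond the scatter.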